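From bromo to trifluoromethyl: compound 3 to compound 4

A few compounds are considered here, and "the series" means these few. Any claim that something is new, unique, unknown or untested is made for them only; others in the source may bear on it.

In a functional assay on B16-F10 cells (Mus musculus) for antiproliferative activity, read by MTT assay, with a stated time of 48 h (a lower number here means a stronger inhibitor, a higher number a weaker inhibitor), compound 1 (`COc1ccc(/C=C/c2cc(OC)cc(OC)c2/C=C/C(=O)c2ccc(C)cc2)cc1`) gives 5.3 ug/mL while compound 2 (`CCCCCCOc1ccc(C(=O)/C=C/c2c(/C=C/c3ccc(OC)cc3)cc(OC)cc2OC)cc1`) gives 10.4 ug/mL and compound 3 (`COc1ccc(/C=C/c2cc(OC)cc(OC)c2/C=C/C(=O)c2ccc(Br)cc2)cc1`) gives 6.5 ug/mL in the same read-out. Compound 3 is not separated from either of the other two. The steps read a 1.2-fold higher number from compound 1 to compound 3 (0.09 log units; within the scatter) and a 1.6-fold lower number from compound 2 to compound 3 (0.20 log units; within the scatter) in this series. Compound 4 (`COc1ccc(/C=C/c2cc(OC)cc(OC)c2/C=C/C(=O)c2ccc(C(F)(F)F)cc2)cc1`) carries trifluoromethyl in place of bromo on an aromatic carbon, para to a large group (trifluoromethyl in place of bromo on an aromatic carbon). Replacing methyl with hexyloxy at this place gives a 2.0-fold higher number from compound 1 to compound 2 (0.29 log units; within the scatter) and so no step beyond the scatter is expected in this assay for this change. The expected step is a 1.1-fold lower number from compound 3 to compound 4 (0.03 log units; within the scatter) on this estimate. Compound 4 is estimated at 6 ug/mL with an expected range of 3.2 ug/mL to 11.5 ug/mL in this read-out.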

Compound 4, half-maximal inhibitory concentration: 4.3 ug/mL
The estimate for compound 4 lay 1.4-fold (0.14 log units) above the measured number, within the range that was stated.
By their numbers in this assay, from the lowest: compounds 4, 1, 3 and 2 (each within the scatter of the next, the first and the last beyond it).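

In this assay, among these compounds, this position now shows a pair that separates: a 2.4-fold lower number from compound 2 to compound 4 (0.38 log units; beyond the scatter) is the only step here beyond the scatter, and it is modest. Trifluoromethyl is not separated from bromo or methyl, with a 1.5-fold lower number from compound 3 to compound 4 (0.18 log units; within the scatter) and a 1.2-fold lower number from compound 1 to compound 4 (0.09 log units; within the scatter) both within the scatter. Only hexyloxy and trifluoromethyl, at the two ends of the order, stand apart at this place.

On these data alone, whether an amine, a carboxylic acid or a chain longer than hexyloxy here would widen that spread remains open. No measurement at hand accounts for the gap between hexyloxy and trifluoromethyl.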